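Pentyl in Place of Cyclopropyl on the Alkyne

The source may hold more compounds than are shown below. What is called first, only, known or untested is meant among the compounds shown, and "the series" means these compounds.

Measured compounds:
Compound 1, `CC(=O)OCC(CCn1cc(C#CC2CC2)c(=O)n(C(=O)c2ccccc2)c1=O)COC(C)=O`: > 100000 nM
Compound 2, `CCCCCC#Cc1cn(CCC(COC(C)=O)COC(C)=O)c(=O)n(C(=O)c2ccccc2)c1=O`: 40700 nM
Compound 3, `O=c1[nH]c(=O)n(CCC(CO)CO)cc1C#CC1CC1`: > 100000 nM

Of the compounds shown here, three have been tested in a functional assay on SW-620 cells (Homo sapiens) for antiproliferative activity, read by MTT assay, with a stated time of 72 h; a lower number here means a stronger inhibitor, a higher number a weaker inhibitor. Compound 1 `CC(=O)OCC(CCn1cc(C#CC2CC2)c(=O)n(C(=O)c2ccccc2)c1=O)COC(C)=O` does not reach a number in this assay but only its limit, > 100000 nM. Compound 2 `CCCCCC#Cc1cn(CCC(COC(C)=O)COC(C)=O)c(=O)n(C(=O)c2ccccc2)c1=O` gives 40700 nM in this assay. Compound 3 `O=c1[nH]c(=O)n(CCC(CO)CO)cc1C#CC1CC1` also stops at the limit of this assay, > 100000 nM.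

The change from compound 1 to compound 2 is pentyl in place of cyclopropyl on a triple-bonded carbon. It produced an at least 2.4-fold lower number from compound 1 to compound 2 (0.39 log units; beyond the scatter); because compound 1 sits at the limit of > 100000 nM in this assay, at which 2 of the 3 values shown sit, only the lower bound of that step is known. The difference between the core of compound 1 and the core of compound 3 is not broken down here.

Compound 4 `CCCCCC#Cc1cn(CCC(CO)CO)c(=O)[nH]c1=O` has not yet been measured. It differs from compound 3 by pentyl in place of cyclopropyl on a triple-bonded carbon, the same change that was made from compound 1 to compound 2, at the same place. Since compound 3 gives only a limit, the reference point for compound 4 is itself uncertain. Resting on the step from compound 1 to compound 2, compound 4 is expected to show an at least 1.2-fold lower number from compound 3 to compound 4 (0.09 log units; that floor lies within the scatter), with a real chance that it too remains at the limit. Compound 4 is estimated at 80000 nM in this assay, expected to lie between 30000 nM and 200000 nM.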

Compound 4, half-maximal inhibitory concentration: > 100000 nM
Compound 4 was reported as a limit; the forecaster's own chance of this, stated with the estimate: 55%; at least 1.2-fold (0.09 log units) between middle value and limit.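

Compound 4 also stops at a limit in this assay, > 100000 nM. The step from compound 3 to compound 4 cannot be read, because both compounds stand at a limit: the limit of > 100000 nM in this assay, at which 3 of the 4 values shown sit.

The compounds shown leave open whether pentyl in place of cyclopropyl on a triple-bonded carbon lowers the number on the core of compound 3, as it did on the core of compound 1.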